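A few compounds are considered here, and "the series" means these few. Any claim that something is new, unique, unknown or untested is made for them only; others in the source may bear on it.

Measured in a physicochemical assay for lipophilicity, at pH 7.4; on this read-out lower numbers stand for lower lipophilicity and higher numbers for higher lipophilicity:
- compound 1 `O=C(O)Cn1nc(Cc2nc3cc(Cl)c(OCC(F)F)cc3[nH]2)c2ccccc2c1=O`: 1.97
- compound 2 `O=C(O)C1(c2nn(Cc3cn4cc(OCC5CC5)c(Cl)cc4n3)c3ccccc3c2=O)CC1`: 2.46
- compound 3 `O=C(O)Cn1nc(Cc2nc3cc(Cl)c(OCC4CC4)cc3[nH]2)c2ccccc2c1=O`: 2.21

Compound 3 sits second highest of the three numbers in this assay; its nearest neighbour is compound 1 and its furthest is compound 2, and both gaps are within the scatter, so no ordering among the three is claimed.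

The next compound, compound 4 `O=C(O)Cn1nc(Cc2nc3cc(Cl)c(OC(F)(F)F)cc3[nH]2)c2ccccc2c1=O`, is not yet measured in this assay. It differs from compound 3 in one place: trifluoromethyl in place of cyclopropylmethyl on an oxygen on an aromatic ring.

Among the compounds with values here, the only measured step that bears on this position is a number 0.24 log units higher from compound 1 to compound 3 (within the scatter), a change on the same oxygen on an aromatic ring that stayed within the scatter. Within the data shown here, nothing measured here separates a trifluoromethyl from a cyclopropylmethyl on that oxygen, so the expectation rests on the single step from compound 1 to compound 3 being small. Accordingly the step of a number 0.09 log units higher from compound 3 to compound 4 (within the scatter) is expected to stay within the scatter, with no clear direction. For compound 4 in this assay the estimate is 2.3, with a range from 1.9 to 2.7.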

Compound 4, distribution coefficient: 2.54
For compound 4 the middle estimate is 0.24 log units below the measured one; measured number inside the range.
By their numbers in this assay, from the lowest: compounds 1, 3, 2 and 4 (each within the scatter of the next, the first and the last beyond it).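

In this assay the oxygen on an aromatic ring now shows steps beyond the scatter: trifluoromethyl in place of cyclopropylmethyl gives a number 0.33 log units higher from compound 3 to compound 4 (beyond the scatter) and trifluoromethyl in place of 2,2-difluoroethyl gives a number 0.57 log units higher from compound 1 to compound 4 (beyond the scatter) whereas the earlier a number 0.24 log units higher from compound 1 to compound 3 (within the scatter) stayed within it. Both new steps are modest and run the same way, so the read-out does respond to the group on this oxygen, and trifluoromethyl is the change that brings this out. Nothing available here accounts for the size or direction of these steps.

Going by these compounds, whether a plain methyl or a longer chain such as butyl on this oxygen would fall in line with these steps remains open. Also open, on these data alone, is whether trifluoromethyl in place of cyclopropylmethyl would give a similar step on the core of compound 2.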